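The compounds below may be only part of what the source reports. "The series", "measured", "known", "first", "only" and "open" are said of these compounds alone.

Measured in a functional assay for inhibition, with a stated time of 30 min; a lower number here means a stronger inhibitor, a higher number a weaker inhibitor:
- compound 1 `O=C(/C=C/c1ccc(O)c(O)c1)OCCOc1no[n+]([O-])c1S(=O)(=O)c1ccccc1`: 221 nM
- compound 2 `O=C(/C=C/c1ccc(O)cc1)OCCOc1no[n+]([O-])c1S(=O)(=O)c1ccccc1`: 41400 nM
- compound 3 `COc1cc(/C=C/C(=O)OCCOc2no[n+]([O-])c2S(=O)(=O)c2ccccc2)ccc1O`: 5130 nM

Compound 3 holds the middle of these three values, with a lower number than compound 2 and a higher one than compound 1. Compound 4 `O=C(/C=C/c1ccccc1)OCCOc1no[n+]([O-])c1S(=O)(=O)c1ccccc1` is reached by phenyl in place of 4-hydroxy-3-methoxyphenyl on a double-bonded chain carbon bound to a double-bonded chain carbon. Among the measured compounds shown here, three measured steps bear on this change. Methoxy in place of hydrogen on an aromatic carbon gave an 8.1-fold lower number from compound 2 to compound 3 (0.91 log units; beyond the scatter), a modest step. Hydrogen in place of hydroxy on an aromatic carbon gave a 190-fold higher number from compound 1 to compound 2 (2.27 log units; beyond the scatter), and methyl in place of hydrogen on an oxygen gave a 23-fold higher number from compound 1 to compound 3 (1.37 log units; beyond the scatter), both large. For the measured compounds named here, no measured compound lacks both the hydroxy and the methoxy, so the size remains uncertain. A modest rise is expected, with a 5.8-fold higher number from compound 3 to compound 4 (0.77 log units; beyond the scatter) as the estimated step. For compound 4 the estimated value is 30000 nM, with an expected range from 6000 nM to 120000 nM.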

Compound 4, half-maximal inhibitory concentration: > 100000 nM
Compound 4: a limit, no number; the forecaster's own chance of this, stated with the estimate: 25%; middle value at least 3.3-fold (0.52 log units) away from the limit.
By their numbers in this assay, from the lowest: compound 1; then compound 3; then compound 2. At a limit, above all of these: compound 4.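

In this assay compound 4 gives > 100000 nM, which is a limit of the assay and not a number. Phenyl in place of 4-hydroxy-3-methoxyphenyl gave an at least 19-fold higher number from compound 3 to compound 4 (1.28 log units; beyond the scatter), and phenyl in place of 3,4-dihydroxyphenyl gave an at least 450-fold higher number from compound 1 to compound 4 (2.65 log units; beyond the scatter). Hydrogen in place of hydroxy gave an at least 2.4-fold higher number from compound 2 to compound 4 (0.38 log units; beyond the scatter), so even the single hydroxy of compound 2 still counts on this ring. Going by these compounds, how far compound 4 lies past its limit stays open, and with it the full size of these steps. On these data alone, whether an amine or a carboxylic acid on the ring could stand in for the hydroxy also remains open.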